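This account rests on a few compounds, and the source may have more. Where it says the series, first, only, none or still open, it means among the compounds named here.

In a physicochemical assay for solubility, using the shake flask method, in simulated intestinal fluid, measured as kinetic solubility, with a stated time of 2 h, at 25 degrees C, at pH 6.5 (a lower number here means a less soluble compound, a higher number a more soluble compound), compound 3 (`Cc1noc(-c2nc(C)c3c(c2N)C(=O)N(Cc2ccccc2C(F)(F)F)C3=O)n1`) stands only at a limit, < 5000 nM, and not at a number. Compound 1 (`COc1ccc(CN2C(=O)c3c(C)nc(-c4nc(C)no4)c(N)c3C2=O)cc1`) likewise gives only a limit, < 5000 nM. Compound 2 (`Cc1noc(-c2nc(C)c3c(c2N)C(=O)N(Cc2ccc(Br)cc2)C3=O)n1`) also gives only a limit, < 5000 nM. Within the data shown here, the series so far therefore shows a single shared ceiling: the limit of < 5000 nM in this assay, at which 3 of the 3 values shown sit.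

The step followed here leads to compound 4 (`Cc1noc(-c2nc(C)c3c(c2N)C(=O)N(Cc2ccc(Cl)cn2)C3=O)n1`), with 5-chloropyridin-2-yl in place of 2-(trifluoromethyl)phenyl on a saturated chain carbon bound to an amide-type nitrogen in a ring.

Two measured steps changed the same place, a step that the two limits leave unreadable from compound 1 to compound 3 and a step that the two limits leave unreadable from compound 2 to compound 3. Neither gives a size that could be carried over, so no direction can be read from them, and only a modest expected step can be proposed in this assay. The estimated change is a step that the limit leaves unreadable from compound 3 to compound 4, and a report at the same limit is the likeliest outcome. For compound 4 the expected value is 3000 nM, with an estimated range of 800 nM to 8000 nM.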

Compound 4, solubility: < 5000 nM
Compound 4: only a limit was reported (the forecaster's own chance of this, stated with the estimate: 80%); the middle value does not contradict the limit.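

In this assay compound 4 gives < 5000 nM, a limit and not a number, and its steps to compound 1, compound 2 and compound 3 cannot be read. The compounds shown leave open what number any of them would reach, and whether the groups exchanged differ at all: the limit of < 5000 nM in this assay, at which 4 of the 4 values shown sit.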